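Capping a Phenol: From Compound 3 to Compound 4

This account rests on a few compounds, and the source may have more. Where it says the series, first, only, none or still open, it means among the compounds named here.

Three compounds have been measured in a functional assay on PC-3 cells (Homo sapiens) for cytotoxicity, read by MTT assay, with a stated time of 48 h; a higher number here means a weaker inhibitor, a lower number a stronger inhibitor:
compound 1 `c1ccc(-c2nc(-c3c[nH]c4ccccc34)co2)cc1` gives 170000 nM;
compound 2 `COc1ccc(-c2nc(-c3c[nH]c4ccccc34)co2)cc1OC` gives 359000 nM;
compound 3 `Oc1ccc(-c2nc(-c3c[nH]c4ccccc34)co2)cc1` gives 382000 nM.

For the measured compounds named here, compound 3 carries the highest number of the three, though its value and that of compound 2 lie within the scatter of each other; only the step of a 2.2-fold higher number from compound 1 to compound 3 (0.35 log units; beyond the scatter) stands beyond it. Compound 4 `COc1ccc(-c2nc(-c3c[nH]c4ccccc34)co2)cc1` differs from compound 3 by methyl in place of hydrogen on an oxygen on an aromatic ring. Going by the values given here, no measured step covers this exact change. The nearest guide is compound 2, whose two methoxy groups give a number close to the hydroxy of compound 3, so a step of a 1.3-fold lower number from compound 3 to compound 4 (0.10 log units; within the scatter) is expected to stay within the scatter. Compound 4 is therefore estimated at 300000 nM, between 150000 nM and 600000 nM.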

Compound 4, half-maximal inhibitory concentration: 133000 nM
Beside the measured number, compound 4's estimate is 2.3-fold (0.35 log units) above it; the measured number lies below the stated range.
By their numbers in this assay, from the lowest: compounds 4 and 1 (each within the scatter of the next); then compounds 2 and 3 (each within the scatter of the next).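

Capping the hydroxy changes the result beyond the scatter (a 2.9-fold lower number from compound 3 to compound 4 (0.46 log units; beyond the scatter)), so the free hydroxy and the methoxy are not interchangeable at this position. The methoxy of compound 4 instead matches the unsubstituted ring (a 1.3-fold lower number from compound 1 to compound 4 (0.11 log units; within the scatter)), while removing the other methoxy of compound 2 gives a clear step (a 2.7-fold lower number from compound 2 to compound 4 (0.43 log units; beyond the scatter)), so compound 2 was a poor guide to this single change. As far as these compounds go, whether an ethoxy group or an amine in this place would also match compound 1 stays open. Nothing here explains why these steps occur.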